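The source may report more compounds than this note shows. Statements on the series, on what has been measured and on what is new or still open speak of the compounds shown alone.

Compound 3 `CCOC(=O)C1=C(C)NC(C)=C(C(=O)OCC)C1c1ccc(OCC(=O)Nc2nc3ccccc3s2)cc1` gives the highest number among the three measured compounds in a functional assay on the whole organism (strain Wistar) for inhibition, with Rattus norvegicus as the target, read by paw edema, with stated times of 30 min and 2 h, at a dose of 20 mg/kg (a higher number here means more inhibition at the dose given (going by the name of the read-out), a lower number less inhibition), at 64.5%. Its nearest neighbour is compound 2 `CCOC(=O)C1=C(C)NC(C)=C(C(=O)OCC)C1c1ccc(OCC(=O)Nc2c(C)cccc2C)cc1`, which in this assay gives 47.8%, and the furthest is compound 1 `CCOC(=O)C1=C(C)NC(C)=C(C(=O)OCC)C1c1ccc(OCC(=O)NCc2ccccc2)cc1`, which in this assay gives 8.9%. The new compound 4 `CCOC(=O)C1=C(C)NC(C)=C(C(=O)OCC)C1c1ccc(OCC(=O)NNC(=O)c2ccc(C)cc2)cc1` differs from compound 3 at one place: ((4-methylphenyl)carbonyl)amino in place of 1,3-benzothiazol-2-yl on an amide-type nitrogen.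

Every measured step concerns the group on this same amide-type nitrogen. Replacing benzyl by an aromatic ring bound directly to that nitrogen gave a number 38.9 percentage points higher from compound 1 to compound 2 (beyond the scatter) and a number 55.6 percentage points higher from compound 1 to compound 3 (beyond the scatter), and between the two aromatic rings there was a number 16.7 percentage points higher from compound 2 to compound 3 (beyond the scatter). In compound 4 the aromatic ring again sits one atom away from that nitrogen, as it does in compound 1, although here through a carbonyl-bearing amino group rather than a methylene. Going by the values given here, no measured step covers such a group, so the direction is read by analogy with compound 1 only. Compound 4 is therefore expected to fall below compound 3 in this assay, by about a number 34.5 percentage points lower from compound 3 to compound 4 (beyond the scatter), landing near 30%, with a range from 10% to 55%.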

Compound 4, a percentage reported as inhibition, in the whole organism at one dose (the size of the read-out at that dose, not a potency): 46.7%
Estimate against measurement, compound 4: 16.7 percentage points below, within the range that was stated.
By their numbers in this assay, from the lowest: compound 1; then compounds 4 and 2 (each within the scatter of the next); then compound 3.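

In this assay, an aromatic ring set one atom away from the amide-type nitrogen does not by itself bring the low number of compound 1: the ((4-methylphenyl)carbonyl)amino group gives a number 37.8 percentage points higher from compound 1 to compound 4 (beyond the scatter). That group still falls short of 1,3-benzothiazol-2-yl, with a number 17.8 percentage points lower from compound 3 to compound 4 (beyond the scatter), whereas against 2,6-dimethylphenyl there is a number 1.1 percentage points lower from compound 2 to compound 4 (within the scatter), so these two groups cannot be ordered. Nothing available offers a reason for any of these steps.

From the compounds shown here alone, it remains open which part of the new group carries its gain over benzyl, the carbonyl, the added amino nitrogen or the methyl on the ring. A plain amine on the amide-type nitrogen, or a chloro group in place of that methyl, would begin to separate these parts.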